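Lengthening the aminoalkyl chain of compound 3

A few compounds are considered here, and "the series" means these few. Any claim that something is new, unique, unknown or untested is made for them only; others in the source may bear on it.

Compound 1 `CN(C)CCCn1c(N)c(-c2nc3ccccc3[nH]2)c2nc(C#N)c(C#N)nc21`: 1730 nM
Compound 2 `CN(C)CCCn1c(N)c(-c2nc3ccccc3s2)c2nc(C#N)c(C#N)nc21`: 1800 nM
Compound 3 `CN(C)CCn1c(N)c(-c2nc3cc(Cl)ccc3[nH]2)c2nc(C#N)c(C#N)nc21`: 11300 nM

In a functional assay on K562 cells (Homo sapiens) for antiproliferative activity, read by MTT assay, with a stated time of 48 h (a higher number here means a weaker inhibitor, a lower number a stronger inhibitor), compound 3 gives 11300 nM, the highest of the three numbers and so the weakest inhibitor here, with both other compounds lower by more than the scatter. Compound 4 `CN(C)CCCn1c(N)c(-c2nc3cc(Cl)ccc3[nH]2)c2nc(C#N)c(C#N)nc21` comes from compound 3 by a single change: (dimethylamino)methyl in place of dimethylamino on a saturated chain carbon, two bonds along the chain from an aromatic nitrogen. Cut one bond further out, the same change reads 2-(dimethylamino)ethyl to 3-(dimethylamino)propyl.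

Going by the values given here, no measured step isolates this change. The only one available, a 1.0-fold higher number from compound 1 to compound 2 (0.02 log units; within the scatter), lies elsewhere on the molecule and within the scatter, so it gives no size to carry over. The indirect guide is that the 3-(dimethylamino)propyl chain of compound 4 also occurs in compound 1 at 1730 nM and in compound 2 at 1800 nM. Both differ from compound 3 in more than the chain, so only part of their gap to compound 3 can be expected to transfer. A moderate move towards a lower number is therefore expected, with wide uncertainty. The estimated change for compound 4 is a 3.2-fold lower number from compound 3 to compound 4 (0.51 log units; beyond the scatter). In this assay compound 4 is expected at 3500 nM, within an estimated range of 1000 nM to 11000 nM.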

Compound 4, half-maximal inhibitory concentration: 10700 nM
Compound 4: middle estimate off by 3.1-fold (0.49 log units), on the low side, and the stated range covers the measured number.
By their numbers in this assay, from the lowest: compounds 1 and 2 (each within the scatter of the next); then compounds 4 and 3 (each within the scatter of the next).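

In this assay, a 1.1-fold lower number from compound 3 to compound 4 (0.02 log units; within the scatter) lies within the scatter, so with the 5-chloro-1H-benzimidazol-2-yl group present, the 2-(dimethylamino)ethyl and 3-(dimethylamino)propyl chains cannot be told apart at this position on the aromatic nitrogen. With the 3-(dimethylamino)propyl chain held constant, the steps beyond the scatter appear at the aromatic carbon instead: chloro in place of hydrogen gives a 6.2-fold higher number from compound 1 to compound 4 (0.79 log units; beyond the scatter), and 5-chloro-1H-benzimidazol-2-yl in place of 1,3-benzothiazol-2-yl gives a 5.9-fold higher number from compound 2 to compound 4 (0.77 log units; beyond the scatter). Nothing available accounts for the absence of a chain step or for the size of the two ring-substituent steps.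

Whether the chain length is equally silent without chloro stays open, since the unsubstituted 1H-benzimidazol-2-yl group is shown only with the 3-(dimethylamino)propyl chain, and a longer 4-(dimethylamino)butyl chain also lies outside the compounds shown. On these data alone, it is likewise open whether the step from hydrogen to chloro is particular to chlorine, as a fluoro or methoxy group in the same place would be needed to show how far it extends.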